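The source may report more compounds than this note shows. Statements on the series, on what has been measured and on what is new or still open speak of the compounds shown alone.

Compound 3 `CC1=C(C(=O)CC(C)C)C(c2ccoc2)NC(=O)N1` gives 1010 nM in an assay on membranes from HEK293 cells for displacement of a labelled ligand from adenosine receptor A2b (Homo sapiens), read by scintillation counting, with a stated time of 30 min; on this read-out higher numbers stand for weaker inhibition and lower numbers for stronger inhibition. Among the three compounds measured there, compound 3 stands second highest: its nearest neighbour is compound 1 `CCCOC(=O)C1=C(C)NC(=O)NC1c1ccoc1`, which gives 1190 nM, and the two numbers lie within the scatter of each other, while compound 2 `CC1=C(C(=O)OCC(C)C)C(c2ccoc2)NC(=O)N1` gives 326 nM and sits furthest from compound 3.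

Compound 4 `CC1=C(C(=O)SC(C)C)C(c2ccoc2)NC(=O)N1` has not yet been measured. It differs from compound 3 in one place: isopropylsulfanyl in place of isobutyl on a carbonyl carbon. Going by the values given here, two measured steps touch the same carbonyl carbon. a 1.2-fold lower number from compound 1 to compound 3 (0.07 log units; within the scatter) shows that exchanging propoxy for isobutyl hardly moves the number, whereas a 3.1-fold higher number from compound 2 to compound 3 (0.49 log units; beyond the scatter) shows that isobutoxy to isobutyl costs a modest amount. Groups attached to that carbonyl carbon through oxygen have thus given the lowest number seen once and an indistinguishable number once; the change to isopropylsulfanyl brings back a group attached through a heteroatom, of the same heavy-atom count as the isobutyl it replaces. Among the compounds with values here, no measured step involves sulfur, so the direction rests on the two ester comparisons only. For compound 4 a downward step, a 2.2-fold lower number from compound 3 to compound 4 (0.35 log units; beyond the scatter), is expected, with a range wide enough to include no change beyond the scatter. Compound 4 is estimated in this assay at 450 nM, within 180 nM to 1300 nM.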

Compound 4, inhibition constant: 637 nM
For compound 4 the middle estimate is 1.4-fold (0.15 log units) below the measured one, within the range that was stated.
By their numbers in this assay, from the lowest: compounds 2, 4, 3 and 1 (each within the scatter of the next, the first and the last beyond it).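

Working notes on the carbonyl carbon substituent, read in this assay: isopropylsulfanyl is the first group here attached through sulfur, and it cannot be told apart from the isobutyl it replaces, with a 1.6-fold lower number from compound 3 to compound 4 (0.20 log units; within the scatter) as the step. It also cannot be told apart from either group attached through oxygen, as the step to isobutoxy (a 2.0-fold higher number from compound 2 to compound 4 (0.29 log units; within the scatter)) and the step to propoxy (a 1.9-fold lower number from compound 1 to compound 4 (0.27 log units; within the scatter)) both stay within the scatter, although the isobutoxy to isobutyl exchange (a 3.1-fold higher number from compound 2 to compound 3 (0.49 log units; beyond the scatter)) lies beyond it, so compound 4 sits in the overlap and does not sharpen the split among the earlier groups. No measurement on hand explains why these groups rank as they do at this position.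

Open, from the compounds shown here alone, is whether a different attachment on the same carbonyl carbon, such as an amine bound through its nitrogen or a carboxylic acid carried on a short chain, would leave the span of numbers covered so far. Also open, going by these compounds, is whether a longer chain on the sulfur, such as butylsulfanyl, would separate from isopropylsulfanyl, and whether the sulfur attachment would read the same with the other parts of the shared core changed.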